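Sulfonyl aryl swap in the acylsulfonamide series

A few compounds are considered here, and "the series" means these few. Any claim that something is new, unique, unknown or untested is made for them only; others in the source may bear on it.

Measured so far in an assay on isolated protein for displacement of a labelled ligand from prostaglandin E2 receptor EP3 subtype (Homo sapiens), read by scintillation counting, with a stated time of 2 h; on this read-out higher numbers stand for weaker inhibition and lower numbers for stronger inhibition:
compound 1 `O=C(NC/C=C1\CCCc2cnn(Cc3ccc(Cl)cc3Cl)c21)NS(=O)(=O)c1ccc(Cl)cc1` gives 4 nM
compound 2 `O=C(NC/C=C1\CCCc2cnn(C3CCN(c4ccc(F)cc4)CC3)c21)NS(=O)(=O)c1cc(Cl)c(Cl)s1` gives 1 nM
compound 3 `O=C(NS(=O)(=O)c1ccc(Cl)cc1)OC/C=C1\CCCc2cnn(Cc3ccc(Cl)cc3Cl)c21` gives 11 nM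

Compound 1 stands second highest of the three numbers; compound 3 sits at a higher number beyond the scatter, and compound 2 at a lower number, also beyond the scatter. Among the compounds with values here, no pair among the three differs in a single place, so no step is counted.

Compound 4 `O=C(NC/C=C1\CCCc2cnn(Cc3ccc(Cl)cc3Cl)c21)NS(=O)(=O)c1cccs1` has not been measured. It differs from compound 1 in one place: thiophen-2-yl in place of 4-chlorophenyl on a sulfonyl sulfur. Without a counted step to lean on, a small move toward a higher number is expected, near the edge of the scatter. The expected step is a 2.0-fold higher number from compound 1 to compound 4 (0.30 log units; within the scatter). For compound 4 the estimate in this assay is 8 nM, within 3 nM to 25 nM.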

Compound 4, inhibition constant: 15 nM
For compound 4 the middle estimate is 1.9-fold (0.27 log units) below the measured one; the measured number falls inside the stated range.
By their numbers in this assay, from the lowest: compound 2; then compound 1; then compounds 3 and 4 (each within the scatter of the next).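

In this assay, within the data shown here, the position on the sulfonyl sulfur proves sensitive to the aryl group: thiophen-2-yl in place of 4-chlorophenyl gives a 3.8-fold higher number from compound 1 to compound 4 (0.57 log units; beyond the scatter) and provides the first single-place step. This step lies beyond the scatter, so this ring swap is not neutral here. No measured evidence accounts for the step.

From the compounds shown here alone, it remains open whether an unsubstituted phenyl or a 5-chlorothiophen-2-yl group on the sulfonyl sulfur would track with compound 1 or with compound 4. Going by these compounds, the size of the step on other cores also remains open.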